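The compounds below may be only part of what the source reports. "The series", "measured", "known", "first", "only" and "open" are said of these compounds alone.

In a functional assay on BGC-823 cells (Homo sapiens) for antiproliferative activity, read by MTT assay, with a stated time of 24 h (a lower number here means a stronger inhibitor, a higher number a weaker inhibitor), compound 1 `O=[N+]([O-])c1ccc(CSc2nnc(-c3ccc4c(c3)OCCO4)n2-c2ccccc2)cc1` gives 48600 nM. Compound 2 `COc1cccc(CSc2nnc(-c3ccc4c(c3)OCCO4)n2-c2ccccc2)c1` gives > 100000 nM, and this is a limit of the assay, not a number. Its place on the scale is therefore known only from one side.

Among the measured compounds shown here, the only measured step is an at least 2.0-fold higher number from compound 1 to compound 2 (0.31 log units; beyond the scatter), with 3-methoxyphenyl in place of 4-nitrophenyl on a saturated chain carbon bound to a sulfur. Going by these compounds, its true size remains open. Compound 3 `Cc1ccc(CSc2nnc(-c3ccc4c(c3)OCCO4)n2-c2ccccc2)cc1`, not yet measured, differs from compound 2 by 4-methylphenyl in place of 3-methoxyphenyl on a saturated chain carbon bound to a sulfur.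

This change removes the group that compound 2 gained in an at least 2.0-fold higher number from compound 1 to compound 2 (0.31 log units; beyond the scatter), though it does not restore the 4-nitrophenyl of compound 1. That single step is thin evidence, so only a modest move towards a lower number in this assay is expected, and compound 3 may well stay unquantified too. The expected change is an at least 1.4-fold lower number from compound 2 to compound 3 (0.15 log units; that floor lies within the scatter). Compound 3 is estimated at 70000 nM, with an expected range from 25000 nM to 130000 nM.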

Compound 3, half-maximal inhibitory concentration: 44300 nM
Compound 3: middle estimate off by 1.6-fold (0.20 log units), on the high side; low and high end bracket the measured number.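

In this assay, the new result shows that a measured number can be had at this place, on a saturated chain carbon bound to a sulfur, without the 4-nitrophenyl group: 4-methylphenyl in place of 3-methoxyphenyl gives an at least 2.2-fold lower number from compound 2 to compound 3 (0.35 log units; beyond the scatter). With methyl in place of nitro on an aromatic carbon, the result is a 1.1-fold lower number from compound 1 to compound 3 (0.04 log units; within the scatter), so among the compounds shown the nitro group is not needed for activity at this level. The true size of the first step stays open, since the value of compound 2 is a limit of the assay and not a number: the limit of > 100000 nM in this assay, at which 1 of the 3 values shown sits.

The step from 3-methoxyphenyl to 4-methylphenyl changes the group and the number in its name at once, and the compounds shown do not separate the two, a question on which a 4-methoxyphenyl group would bear. Also open, going by these compounds, is how an amine or a carboxylic acid in place of the methyl would read in this assay, and whether any group at this place gives a much lower number.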